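A Larger Aryl Group on the Double-Bonded Chain

The source may report more compounds than this note shows. Statements on the series, on what has been measured and on what is new or still open speak of the compounds shown alone.

Of the compounds shown here, two of one shared core have been measured. Compound 1 `COc1ccc(/C=C/C(=O)c2cc(-c3ccc(OC)c(OC)c3)n3nc(-c4ccccc4)cc3n2)cc1` in a functional assay on MDA-MB-231 cells (Homo sapiens) for antiproliferative activity, read by MTT assay, with a stated time of 24 h (on this read-out lower numbers stand for stronger inhibition and higher numbers for weaker inhibition), gives 22000 nM. Compound 2 `COc1ccc(-c2cc(C(=O)/C=C/c3ccc(C)cc3)nc3cc(-c4ccccc4)nn23)cc1OC` in this assay gives 22600 nM. Among the compounds with values here, the single step between them, a 1.0-fold higher number from compound 1 to compound 2 (0.01 log units; within the scatter), is methyl in place of methoxy on an aromatic carbon. Compound 2 thus holds the highest of the two numbers shown, but its nearest neighbour, compound 1, sits within the scatter of it, so the two cannot be separated on this read-out.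

Compound 3 `COc1ccc(-c2cc(C(=O)/C=C/c3cc(OC)c(OC)c(OC)c3)nc3cc(-c4ccccc4)nn23)cc1OC` is not yet measured. It differs from compound 2 by 3,4,5-trimethoxyphenyl in place of 4-methylphenyl on a double-bonded chain carbon bound to a double-bonded chain carbon. Within the data shown here, only one measured step bears on this change, the step from compound 1 to compound 2 on the same aryl group, and that step stayed within the scatter. Among the measured compounds shown here, no measured step covers a replacement of this size, so the expectation rests on that one small step alone. The step of a 1.5-fold lower number from compound 2 to compound 3 (0.18 log units; within the scatter) is therefore expected to be small, at most a modest move toward a lower number. Compound 3 is estimated at 15000 nM, with a range from 4000 nM to 45000 nM.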

Compound 3, half-maximal inhibitory concentration: 16700 nM
Beside the measured number, compound 3's estimate is 1.1-fold (0.05 log units) below it, within the range that was stated.
By their numbers in this assay, from the lowest: compounds 3, 1 and 2 (each within the scatter of the next).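

At this position, on a double-bonded chain carbon bound to a double-bonded chain carbon, the earlier pair covered only the exchange of 4-methoxyphenyl and 4-methylphenyl, whereas 3,4,5-trimethoxyphenyl brings 12 heavy atoms in place of 7 and 3 hydrogen-bond acceptors in place of 0. Even so, in this assay this much larger replacement gives a 1.4-fold lower number from compound 2 to compound 3 (0.13 log units; within the scatter) and, measured against the 4-methoxyphenyl group, gives a 1.3-fold lower number from compound 1 to compound 3 (0.12 log units; within the scatter) so the position accepts this added size and these added oxygen atoms with no difference that can be told from the scatter, and the three aryl groups remain inseparable on this read-out. Nothing measured here offers an explanation for this flat result.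

Every group shown at this position is a phenyl ring carrying only methyl or methoxy groups, so it remains open whether a hydroxyl, an amine or a carboxylic acid on that ring would move the number beyond the scatter. From the compounds shown here alone, it is also open whether a pyridine ring in place of the phenyl ring would do so.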